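Lengthening the Chain on Compound 1

The source may hold more compounds than are shown below. What is called first, only, known or untested is meant among the compounds shown, and "the series" means these compounds.

For the measured compounds named here, in a functional assay on brain (Rattus norvegicus, strain Wistar) for inhibition (on this read-out higher numbers stand for weaker inhibition and lower numbers for stronger inhibition), compound 1 `CCCc1ccc(-c2c(C)[nH]c(=O)n2C)cc1` gives 21500 nM, the higher of the two numbers measured so far. Compound 2 `CCCCCOc1ccc(-c2c(C)[nH]c(=O)n2C)cc1` gives 4500 nM. Compound 3 `CCCCCCCCCCc1ccc(-c2c(C)[nH]c(=O)n2C)cc1` differs from compound 1 by heptyl in place of hydrogen on a saturated chain carbon, three bonds along the chain from an aromatic carbon. Going by the values given here, only one measured step bears on this change: a 4.8-fold lower number from compound 1 to compound 2 (0.68 log units; beyond the scatter), which puts pentyloxy in place of propyl. On that single modest step, a lower number of similar or somewhat larger size is expected in this assay, though one step is thin evidence. The expected step is a 7.2-fold lower number from compound 1 to compound 3 (0.86 log units; beyond the scatter). For compound 3 the estimate is 3000 nM, with an expected range of 700 nM to 15000 nM.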

Compound 3, half-maximal inhibitory concentration: 7900 nM
For compound 3 the middle estimate is 2.6-fold (0.42 log units) below the measured one; the range from low to high includes it.
By their numbers in this assay, from the lowest: compounds 2 and 3 (each within the scatter of the next); then compound 1.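

Adding heptyl to the end of the propyl chain also lowers the number in this assay, with a 2.7-fold lower number from compound 1 to compound 3 (0.43 log units; beyond the scatter), so this position tolerates a much longer chain without any loss of inhibition. Compound 3 also shows that a chain made only of carbon can give a step beyond the scatter, with no oxygen atom in it. Nothing here explains why the longer chain lowers the number.

Going by these compounds, whether chains of intermediate length do better remains open. So does the effect of an amine or a carboxylic acid at the chain's end.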